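Swapping an Open-Chain Amide for a Ring Amide

The source may report more compounds than this note shows. Statements on the series, on what has been measured and on what is new or still open speak of the compounds shown alone.

Of the compounds shown here, two have so far been measured in an assay on cells for inhibition of Palmitoleoyl-protein carboxylesterase NOTUM variant C330S (Homo sapiens), read by fluorescence, with a stated time of 40 min; a lower number here means a stronger inhibitor, a higher number a weaker inhibitor. Compound 1 `COc1cccc(-n2c(C)cc(C(=O)O)c2C)c1` gives 1500 nM. Compound 2 `COCCNC(=O)C1CCN(c2ccc(Cl)c(C(F)(F)F)c2)C1` gives 3500 nM, the higher of the two numbers and so the weaker inhibitor, and the gap between compound 1 and compound 2 lies beyond the usual scatter of this assay. The two share no common core, so their numbers say nothing about any single structural change.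

Compound 3 `O=C(C1CCN(c2ccc(Cl)c(C(F)(F)F)c2)C1)N1CCOCC1` differs from compound 2 in one place: morpholin-4-yl in place of (2-methoxyethyl)amino on a carbonyl carbon. The open chain that held the single hydrogen-bond donor is thus closed into a ring, and that donor disappears, while one hydrogen-bond acceptor remains on each side.

For the measured compounds named here, no measured pair shows the effect of this exchange, so there is no direct guide. With the rest of compound 2 kept, a step in either direction no larger than the scatter is the most reasonable expectation. Compound 3 is therefore expected to give about 4000 nM in this assay, within a range from 1500 nM to 11000 nM. That expected number means a step of a 1.1-fold higher number from compound 2 to compound 3 (0.06 log units; within the scatter).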

Compound 3, half-maximal inhibitory concentration: 9700 nM
Beside the measured number, compound 3's estimate is 2.4-fold (0.38 log units) below it; low and high end bracket the measured number.
By their numbers in this assay, from the lowest: compound 1; then compound 2; then compound 3.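

For the compounds shown here, the step at this position is the first that can be read as a single structural change. In this assay, morpholin-4-yl in place of (2-methoxyethyl)amino on the carbonyl carbon gives a 2.8-fold higher number from compound 2 to compound 3 (0.44 log units; beyond the scatter) and so a weaker inhibitor, which shows that the group at this place affects the read-out. The change closes the open chain into a six-membered ring, removes the hydrogen-bond donor, keeps the count of hydrogen-bond acceptors and adds one heavy atom, and nothing measured here says which of these differences accounts for the step.

The compounds shown leave open whether the ring or the missing donor matters more: a cyclopentylamino group would keep the amide hydrogen while bringing in a ring, and a dimethylamino group would lack that hydrogen without any ring. They also leave open whether the ring oxygen of morpholin-4-yl plays any part, which a comparison with piperidin-1-yl, the same ring with a carbon in place of that oxygen, could address.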